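A few compounds are considered here, and "the series" means these few. Any claim that something is new, unique, unknown or untested is made for them only; others in the source may bear on it.

Measured compounds:
compound 1 `COc1cc(OC)c(/C=C/S(=O)(=O)Cc2ccc(Cl)cc2)c(OC)c1` — 10000 nM
compound 2 `COc1ccc(CS(=O)(=O)/C=C/c2ccc(N)cc2)cc1` — > 20000 nM

In a functional assay on BT-20 cells (Homo sapiens) for antiproliferative activity, read by trypan blue exclusion (a lower number here means a stronger inhibitor, a higher number a weaker inhibitor), compound 1 gives 10000 nM. Among the compounds with values here, this is the only number reported in this assay; the other value is a limit. Compound 2 in this assay reaches only > 20000 nM, which is a limit of the assay and not a measured number, as noted in the limit of > 20000 nM in this assay, at which 1 of the 2 values shown sits. Compound 1 therefore stands as the sole compound with a defined value, and nothing in the shown data says whether compound 2 is weaker or stronger than it.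

Compound 3 `COc1ccc(CS(=O)(=O)/C=C/c2c(OC)cc(OC)cc2OC)cc1` has not been measured. It differs from compound 1 in one place: methoxy in place of chloro on an aromatic carbon. Within the data shown here, no measured pair in the set shows what this exchange does in this assay. Compound 2 carries the same methoxy-substituted benzyl group but a different styrene part and gives only a limit, so it offers no direct guidance.

Among the measured compounds shown here, with no measured step to lean on, the expected step from compound 1 to compound 3 is a 1.4-fold higher number from compound 1 to compound 3 (0.15 log units; within the scatter), essentially none beyond the scatter. Compound 3 is estimated at 14000 nM in this assay, within a range from 5000 nM to 40000 nM, with a real chance that only a limit is reported.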

Compound 3, half-maximal inhibitory concentration: 20 nM
Compound 3: middle estimate off by 700-fold (2.85 log units), on the high side, and the stated range ends above it.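

In this assay the change from 4-chlorophenyl to 4-methoxyphenyl gives a 500-fold lower number from compound 1 to compound 3 (2.70 log units; beyond the scatter) and so turns a weak antiproliferative compound into a strong one. Before this result no measured pair spoke to this position, and the step now shows that the group on this aromatic carbon, para to a large group, matters greatly in this series: one exchange, with the rest of the core unchanged, is enough to produce a change well beyond the scatter. Nothing in the data shown accounts for the size of this step.

Only this one exchange is shown at this position, so it remains open whether a smaller group such as fluoro, a hydroxy, an ethoxy or an amine in the same place would keep the gain, or whether methoxy itself is needed. Compound 2 gives only > 20000 nM in this assay and that is a limit of the assay and not a number, so whether the benefit of the methoxy group holds with a different styrene part also stays unresolved.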